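The source may hold more compounds than are shown below. What is called first, only, known or untested is meant among the compounds shown, and "the series" means these compounds.

Measured so far:
compound 1, `Cc1cc(C(=O)O)ccc1OCCCCOc1ccc(C(=O)CC(C)C)c(O)c1C`: 42.1%
compound 2, `Cc1cc(C(=O)O)ccc1OCCCCOc1ccc(C(=O)C(C)C)c(O)c1C`: 25.2%
compound 3, `CCC(=O)c1ccc(OCCCCOc2ccc(C(=O)O)cc2C)c(C)c1O`: 22.7%

All three were tested in an assay on HEK293 cells for positive allosteric modulation of metabotropic glutamate receptor 3 (Rattus norvegicus), read by thallium flux, with a stated time of 2.5 min; on this read-out lower numbers stand for smaller maximal responses and higher numbers for larger maximal responses. Compound 3 stands lowest of the three, though only the gap to compound 1 is meaningful: the nearest step is a number 2.5 percentage points lower from compound 2 to compound 3 (within the scatter), and the furthest is a number 19.4 percentage points lower from compound 1 to compound 3 (beyond the scatter). Compound 4, `CC(=O)c1ccc(OCCCCOc2ccc(C(=O)O)cc2C)c(C)c1O`, differs from compound 3 in one place: hydrogen in place of methyl on a saturated chain carbon bound to a carbonyl carbon. For the measured compounds named here, two measured steps bear on this. The most similar change, a number 2.5 percentage points lower from compound 2 to compound 3 (within the scatter), gave nothing beyond the scatter, while the larger change a number 19.4 percentage points lower from compound 1 to compound 3 (beyond the scatter) did lower the value. For compound 4 a small downward step is therefore expected, a number 4.7 percentage points lower from compound 3 to compound 4 (within the scatter), probably within the scatter. Compound 4 is estimated at 18%, between 8% and 30%.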

Compound 4, largest response reached (reported as percent of maximum), in percent of the reference or control that the assay uses: 25.4%
Compound 4: middle estimate off by 7.4 percentage points, on the low side; the range from low to high includes it.
By their numbers in this assay, from the lowest: compounds 3, 2 and 4 (each within the scatter of the next); then compound 1.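

Removing the methyl, which turns propanoyl into acetyl, gives no real change in this assay: the step is a number 2.7 percentage points higher from compound 3 to compound 4 (within the scatter). Acetyl also matches the isopropyl ketone, with a number 0.2 percentage points higher from compound 2 to compound 4 (within the scatter), while the isobutyl ketone remains apart, with a number 16.7 percentage points lower from compound 1 to compound 4 (beyond the scatter), so among these four compounds only compound 1 differs beyond the scatter, and shortening the chain past isopropyl brings no further drop. No measurement here explains this pattern. Going by these compounds, whether a longer chain such as pentyl, or an amine on the carbonyl carbon, would exceed compound 1 remains open.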